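Sulfone-to-amide swap on the shared core

The compounds below may be only part of what the source reports. "The series", "measured", "known", "first", "only" and "open" are said of these compounds alone.

Measured so far:
compound 1 `CS(=O)(=O)c1cncc(-c2ccc3ncc(-c4ccc(S(C)(=O)=O)nc4)n3n2)c1` gives 52000 nM
compound 2 `CS(=O)(=O)c1ccc(-c2cnc3ccc(-c4cccc(S(=O)(=O)CCO)c4)nn23)cc1` gives 190000 nM
compound 3 `C[S+]([O-])c1cccc(-c2ccc3ncc(-c4ccc(C(N)=O)cc4)n3n2)c1` gives 112000 nM

In a physicochemical assay for solubility, at pH 2 (a lower number here means a less soluble compound, a higher number a more soluble compound), compound 2 gives the highest of the three numbers. Against compound 3 the gap is within the scatter of the method, so no order between compound 2 and compound 3 can be claimed. Against compound 1 the gap is beyond the scatter, so compound 2 does stand higher than compound 1.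

The next compound in the series is compound 4 `CS(=O)(=O)c1ccc(-c2cnc3ccc(-c4cccc(C(=O)NCCO)c4)nn23)cc1`. It differs from compound 2 in one place: (2-hydroxyethyl)carbamoyl in place of (2-hydroxyethyl)sulfonyl on an aromatic carbon. In words, (2-hydroxyethyl)carbamoyl in place of (2-hydroxyethyl)sulfonyl on an aromatic carbon.

Among the compounds with values here, no pair of measured compounds shows this change, so there is no measured step to lean on. The hydroxyethyl chain is kept and only the group that carries it is exchanged. The expectation is a step from compound 2 to compound 4 of a 1.3-fold lower number from compound 2 to compound 4 (0.10 log units; within the scatter) in this assay, which is no change beyond the scatter. For compound 4 the estimated value in this assay is 150000 nM, expected to fall between 60000 nM and 400000 nM.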

Compound 4, solubility: > 200000 nM
Compound 4: a limit, no number (the forecaster's own chance of this, stated with the estimate: 10%); middle value at least 1.3-fold (0.12 log units) away from the limit.
By their numbers in this assay, from the lowest: compound 1; then compounds 3 and 2 (each within the scatter of the next). At a limit, above all of these: compound 4.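

In this assay compound 4 gives > 200000 nM, which is a limit of the assay and not a number. This gives the series its first single-place comparison, with the step of an at least 1.0-fold higher number from compound 2 to compound 4 (0.02 log units; that floor lies within the scatter), so on this aromatic carbon, meta to a large group, (2-hydroxyethyl)carbamoyl in place of (2-hydroxyethyl)sulfonyl brings no drop in the number. Only a floor can be given for this step, because compound 4 sits at a limit: the limit of > 200000 nM in this assay, at which 1 of the 4 values shown sits.

Going by these compounds, how far compound 4 really stands from compound 2 remains open, and whether the floor hides a real rise cannot be told. Also open, on these data alone, is whether the same place keeps its number with a carboxylic acid, an amine at the end of the chain, or a longer chain on the carbamoyl.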